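Side-chain swap in the middle of an epoxyketone

The compounds below may be only part of what the source reports. "The series", "measured", "known", "first", "only" and "open" are said of these compounds alone.

Compound 3 `COC[C@H](NC(=O)c1cc(C)on1)C(=O)N[C@H](C(=O)N[C@@H](CC(C)C)C(=O)[C@@]1(C)CO1)C(C)C`: 636 nM
Compound 2 `CC[C@H](NC(=O)[C@H](COC)NC(=O)c1cc(C)on1)C(=O)N[C@@H](CC(C)C)C(=O)[C@@]1(C)CO1`: 468 nM
Compound 1 `COC[C@H](NC(=O)c1cc(OC)no1)C(=O)N[C@@H](COC)C(=O)N[C@@H](CC(C)C)C(=O)[C@@]1(C)CO1`: 82 nM

In a functional assay on MES-SA cells (Homo sapiens) for cytotoxicity, read by luminescence and CellTiter-Glo, with a stated time of 72 h (a lower number here means a stronger inhibitor, a higher number a weaker inhibitor), compound 3 gives 636 nM, the highest of the three numbers. Its nearest neighbour is compound 2, and the change a 1.4-fold higher number from compound 2 to compound 3 (0.13 log units; within the scatter) lies within the scatter. Compound 1 differs from compound 3 in several places; in this assay compound 1 gives 82 nM, a gap that is beyond the scatter.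

Compound 4 `COC[C@H](NC(=O)c1cc(C)on1)C(=O)N[C@@H](CC#N)C(=O)N[C@@H](CC(C)C)C(=O)[C@@]1(C)CO1` differs from compound 3 by cyanomethyl in place of isopropyl on a saturated chain carbon bound to an amide-type nitrogen and a carbonyl carbon. Among the compounds with values here, no measured step covers this exact change: the only single-place step, from compound 2 to compound 3, exchanges methyl for hydrogen at another position and is within the scatter, and compound 1 changes several places at once. With that thin basis the expected step of a 1.6-fold lower number from compound 3 to compound 4 (0.20 log units; within the scatter) is no more than the scatter allows, in either direction. Compound 4 is therefore estimated at 400 nM in this assay, with a range from 150 nM to 1100 nM.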

Compound 4, half-maximal inhibitory concentration: 941 nM
The estimate for compound 4 lay 2.4-fold (0.37 log units) below the measured number, within the range that was stated.
By their numbers in this assay, from the lowest: compound 1; then compounds 2, 3 and 4 (each within the scatter of the next).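

At the saturated chain carbon bound to an amide-type nitrogen and a carbonyl carbon, this assay shows cyanomethyl in place of isopropyl as a 1.5-fold higher number from compound 3 to compound 4 (0.17 log units; within the scatter), so replacing a branched hydrocarbon group with one carrying a nitrile leaves the number within the scatter. Cyano in place of methyl at the end of the side chain gives a 2.0-fold higher number from compound 2 to compound 4 (0.30 log units; within the scatter), which extends the earlier finding for methyl in place of hydrogen to a change that brings in nitrogen and a triple bond. Nothing measured here offers an explanation for these results.

As far as these compounds go, whether an amine, a carboxylic acid or a longer chain at this position would also stay within the scatter remains open. The compounds shown also leave open which of its several differences goes with the value of compound 1, 82 nM.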